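Methoxy for fluoro on the aryl ring: one step

A few compounds are considered here, and "the series" means these few. Any claim that something is new, unique, unknown or untested is made for them only; others in the source may bear on it.

Measured compounds:
compound 1 `Cc1ccc(NC(=S)NC(=O)c2cn(-c3ccccc3)nc2-c2ccc(F)cc2)cc1` — 2980 nM
compound 2 `O=C(NC(=S)Nc1ccc(F)cc1)c1cn(-c2ccccc2)nc1-c1ccc(F)cc1` — 3240 nM

In a functional assay on NCI-H460 cells (Homo sapiens) for inhibition, read by CCK-8 assay, with a stated time of 48 h (a lower number here means a stronger inhibitor, a higher number a weaker inhibitor), compound 1 gives 2980 nM, the lowest of the two numbers, and compound 2 gives 3240 nM; the two lie within the scatter of each other, so no order between them can be read. For the measured compounds named here, the only measured step, a 1.1-fold higher number from compound 1 to compound 2 (0.04 log units; within the scatter), concerns the other aryl ring of the shared core and is within the scatter.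

Compound 3 `COc1ccc(-c2nn(-c3ccccc3)cc2C(=O)NC(=S)Nc2ccc(C)cc2)cc1` differs from compound 1 as follows: methoxy in place of fluoro on an aromatic carbon. Going by the values given here, no measured pair changes this ring, so nothing bears directly on the step; the one step that exists, from compound 1 to compound 2, showed no movement beyond the scatter. The expected step for compound 3 in this assay is therefore a 1.0-fold higher number from compound 1 to compound 3 (0.00 log units; within the scatter), with no direction beyond the scatter. Compound 3 is estimated at 3000 nM, within 1200 nM to 8000 nM.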

Compound 3, half-maximal inhibitory concentration: 2880 nM
Compound 3: the middle estimate sits 1.0-fold (0.02 log units) above what was measured; the range from low to high includes it.
By their numbers in this assay, from the lowest: compounds 3, 1 and 2 (each within the scatter of the next).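

The step from 4-fluorophenyl to 4-methoxyphenyl gives a 1.0-fold lower number from compound 1 to compound 3 (0.01 log units; within the scatter) in this assay, so at this place, para to a large group, methoxy with its hydrogen-bond acceptor reads the same as fluoro within the scatter. For the compounds shown here, this is the first measured step on this ring, and with the earlier step on the other aryl ring, neither of the two rings has yet given a step beyond the scatter. No evidence is available that bears on this result.

As far as these compounds go, whether this place stays as flat with an amine, a carboxylic acid or a longer chain such as butoxy remains open. Also open, from the compounds shown here alone, is whether any substituent on the unsubstituted phenyl of the shared core would give a step beyond the scatter.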